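Hydroxy in Place of Trifluoromethyl on the Biaryl Tail

The source may hold more compounds than are shown below. What is called first, only, known or untested is meant among the compounds shown, and "the series" means these compounds.

Compound 1 `CN(CC1=CC[C@H]2C[C@@H]1C2(C)C)Cc1ccccc1` gives 15800 nM in an assay on HEK293 cells for displacement of a labelled ligand from C-X-C chemokine receptor type 3 (Homo sapiens); on this read-out higher numbers stand for weaker inhibition and lower numbers for stronger inhibition. Compound 2 `CN(CC1=CC[C@H]2C[C@@H]1C2(C)C)Cc1ccc(-c2cccc(F)c2)cc1` gives 2510 nM in this assay, and the step of a 6.3-fold lower number from compound 1 to compound 2 (0.80 log units; beyond the scatter) lies beyond the scatter. For compound 3 `CN(CC1=CC[C@H]2C[C@@H]1C2(C)C)Cc1ccc(-c2cccc(C(F)(F)F)c2)cc1` this assay reports only a limit, > 316 nM, so compound 3 stands at the limit of > 316 nM in this assay, at which 1 of the 3 values shown sits. The step that the limit leaves unreadable from compound 2 to compound 3 therefore cannot be sized. Compound 4 `CN(CC1=CC[C@H]2C[C@@H]1C2(C)C)Cc1ccc(-c2cccc(O)c2)cc1` differs from compound 3 by hydroxy in place of trifluoromethyl on an aromatic carbon. Going by the values given here, only one readable step exists, a 6.3-fold lower number from compound 1 to compound 2 (0.80 log units; beyond the scatter), and it concerns a different change; the fluoro-to-trifluoromethyl step is unreadable. The step that the limit leaves unreadable from compound 3 to compound 4 is therefore expected with wide uncertainty and no firm direction. Compound 4 is expected to give 3000 nM, between 800 nM and 12000 nM, in this assay.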

Compound 4, inhibition constant: > 316 nM
Compound 4 ended at the assay's limit; the forecaster's own chance of this, stated with the estimate: 50%; the middle value is on the limit's open side.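

In this assay compound 4 gives > 316 nM, which is a limit. Its steps from compound 1, compound 2 and compound 3 therefore cannot be read. The compounds shown leave open whether hydroxy, fluoro or trifluoromethyl gives the lowest number.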